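Difluorophenyl in Place of Dimethylphenyl on the Sulfonamide

A few compounds are considered here, and "the series" means these few. Any claim that something is new, unique, unknown or untested is made for them only; others in the source may bear on it.

Compound 1 `COc1cc(C)ccc1S(=O)(=O)N1CCC(N2CCC(C)CC2)CC1` in a functional assay on DLD-1 cells (Homo sapiens) for antiproliferative activity, read by CellTiter-Glo, with a stated time of 72 h; a lower number here means a stronger inhibitor, a higher number a weaker inhibitor: compound 1 gives > 5000 nM, a limit of the assay, not a number.
Compound 2 `Cc1ccc(S(=O)(=O)N2CCC(N3CCC(C)CC3)CC2)cc1C`: compound 2 gives 24 nM.
Compound 3 `Cc1cc(C)c(S(=O)(=O)N2CCC(N3CCC(Cc4ccc(F)cc4)CC3)CC2)c(C)c1`: compound 3 gives 18 nM.

Only two of the three results in this assay are numbers, and compound 2 holds one of them. Its nearest neighbour is compound 3, whose number lies within the usual scatter of compound 2, so the two cannot be put in order. For compound 1 the assay reports only the limit described in the limit of > 5000 nM in this assay, at which 1 of the 3 values shown sits, and that result is set aside in what follows.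

Compound 4 `CC1CCN(C2CCN(S(=O)(=O)c3ccc(F)cc3F)CC2)CC1` keeps the whole of the shared core of compound 2 and changes only the aryl group on the sulfonyl sulfur: 2,4-difluorophenyl in place of 3,4-dimethylphenyl on a sulfonyl sulfur. Among the compounds with values here, no measured pair differs in exactly this way, so the size of the step has to be judged from the structures alone. The step is estimated at a 6.3-fold higher number from compound 2 to compound 4 (0.80 log units; beyond the scatter), toward a weaker inhibitor by a moderate amount. On that basis compound 4 is estimated to give 150 nM in this assay, with a likely range from 40 nM to 800 nM.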

Compound 4, half-maximal inhibitory concentration: 102 nM
Compound 4: the middle estimate sits 1.5-fold (0.17 log units) above what was measured; the measured number falls inside the stated range.
By their numbers in this assay, from the lowest: compounds 3 and 2 (each within the scatter of the next); then compound 4. At a limit, above all of these: compound 1.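

Within the data shown here, putting 2,4-difluorophenyl in place of 3,4-dimethylphenyl on a sulfonyl sulfur gives a 4.3-fold higher number from compound 2 to compound 4 (0.63 log units; beyond the scatter) in this assay, and this is the first single-place change at this position that can be read as a step. It shows that the number in this assay responds to the aryl group here even when the two groups have the same count of heavy atoms, yet compound 4 still gives a measured value of 102 nM rather than a limit, so this position tolerates the 2,4-difluorophenyl group to a measurable degree. Nothing given here bears on why the two aryl groups differ in this way.

The compounds shown leave open whether a chlorine, a trifluoromethyl group or a single fluorine on the phenyl ring would give a number closer to that of compound 2 or of compound 4. They also leave open whether the same exchange would produce a step of similar size on the core of compound 3, which carries a different group at the far end of the molecule.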